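The compounds below may be only part of what the source reports. "The series", "measured", "known", "first", "only" and "open" are said of these compounds alone.

Compound 2 `CCn1c(CNc2ccccc2)nnc1SCC(=O)Nc1ccc(C(=O)NC)cc1` was tested in an assay on isolated protein for inhibition of long-chain fatty acid transport protein 1 (Mus musculus) (a lower number here means a stronger inhibitor, a higher number a weaker inhibitor), where compound 2 gives > 10000 nM. That figure is a limit of this assay rather than a measured number, and compound 2 is one of the entries that sit at the limit of > 10000 nM in this assay, at which 1 of the 3 values shown sits. Compound 1 `CCn1c(CNc2ccccc2)nnc1SCC(=O)Nc1ccc(C(=O)OC)cc1` is a close relative, yet in this assay compound 1 gives "not determined" (no result reported), so no number exists for it. For the measured compounds named here, compound 3 `CCC(O)c1ccc2oc(CSc3nnc(CNc4ccccc4)n3CC)nc2c1`, built on a different framework, is the only one with an actual number: in this assay compound 3 gives 3700 nM. Compound 4 `CCn1c(CNc2ccccc2)nnc1SCC(=O)Nc1ccc(C(=O)OC(C)(C)C)cc1` has not yet been measured. It differs from compound 2 in one place: tert-butoxy in place of methylamino on a carbonyl carbon. Going by the values given here, no measured pair shows how large such a step is. Because compound 2 already sits at the limit of > 10000 nM in this assay, at which 1 of the 3 values shown sits, compound 4 is expected to remain near that limit, with the step from compound 2 to compound 4 expected to be a step that the limit leaves unreadable from compound 2 to compound 4. Compound 4 is therefore estimated at 15000 nM, ranging from 4000 nM to 60000 nM.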

Compound 4, half-maximal inhibitory concentration: > 10000 nM
Compound 4: a limit, no number; the forecaster's own chance of this, stated with the estimate: 70%; the middle value is on the limit's open side.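

Compound 4, like compound 2, stands at a limit in this assay, so no size can be read for the step between them: the limit of > 10000 nM in this assay, at which 2 of the 4 values shown sit.

The compounds shown leave open how strongly either one inhibits, and whether tert-butoxy in place of methylamino on a carbonyl carbon changes inhibition at all.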